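Aryl urea variation on the shared core, antiproliferative read-out

The source may hold more compounds than are shown below. What is called first, only, known or untested is meant among the compounds shown, and "the series" means these compounds.

Measured so far:
- compound 1 `Cc1ccc(NC(=O)Nc2cccc(CNc3ncnc4ccccc34)c2)cc1`; in a functional assay on HepG2 cells (Homo sapiens) for antiproliferative activity, read by MTT assay (a lower number here means a stronger inhibitor, a higher number a weaker inhibitor), compound 1 gives > 50000 nM, a limit of the assay.
- compound 2 `O=C(Nc1cccc(CNc2ncnc3ccccc23)c1)Nc1ccccc1Cl`; in this assay compound 2 gives > 50000 nM, a limit of the assay.

Compound 2 therefore stands only at a limit, with no number behind it. For the measured compounds named here, the one measured step, a step that the two limits leave unreadable from compound 1 to compound 2, cannot be read because both ends sit at the limit of > 50000 nM in this assay, at which 2 of the 2 values shown sit.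

Compound 3 `O=C(Nc1cccc(CNc2ncnc3ccccc23)c1)Nc1cccc(C(F)(F)F)c1` differs from compound 2 by 3-(trifluoromethyl)phenyl in place of 2-chlorophenyl on an amide-type nitrogen. Going by the values given here, the only step on record touches the same amide-type nitrogen, yet its size is unreadable, so no direction or size beyond the scatter can be taken from it. Both measured aryl ureas on this core sit at the limit, and the expectation for compound 3 is a result of the same kind.

Compound 3 is estimated at 60000 nM, with a range from 15000 nM to 250000 nM. The step that the limit leaves unreadable from compound 2 to compound 3 is thus expected to be essentially nil.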

Compound 3, half-maximal inhibitory concentration: 40000 nM
Compound 3: the middle estimate sits 1.5-fold (0.18 log units) above what was measured; measured number inside the range.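

With 3-(trifluoromethyl)phenyl on the amide-type nitrogen, the series gains its first number rather than a limit in this assay. The result is an at least 1.2-fold lower number from compound 2 to compound 3 (0.09 log units; that floor lies within the scatter), and against the 4-methylphenyl group it is an at least 1.2-fold lower number from compound 1 to compound 3 (0.09 log units; that floor lies within the scatter); both are floors only, so neither establishes a real difference, though the true gaps could be larger. These floors cannot be sharpened, and the step between the other two compounds cannot be read, because of the limit: the limit of > 50000 nM in this assay, at which 2 of the 3 values shown sit.

Open, as far as these compounds go, is whether any aryl group on this nitrogen gives a clearly stronger result, for instance a phenyl ring carrying a carboxylic acid or a dimethylamino group. Also open, from the compounds shown here alone, is whether the urea itself matters, which an amide in its place would test.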